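Nitro on the benzyl group of compound 3

The compounds below may be only part of what the source reports. "The series", "measured", "known", "first", "only" and "open" are said of these compounds alone.

Values in a functional assay on SK-OV-3 cells (Homo sapiens) for inhibition, read by CCK-8 assay, with a stated time of 70 h (on this read-out lower numbers stand for stronger inhibition and higher numbers for weaker inhibition), so far:
- compound 1 `Clc1ccc(COc2ccc(OCCOCCNC3CCCCC3)cc2)cc1` at 2650 nM
- compound 2 `OCCOCCOCCOc1ccc(OCc2ccccc2)cc1` at 59400 nM
- compound 3 `c1ccc(COc2ccc(OCCOCCNC3CCCCC3)cc2)cc1` at 7370 nM

Compound 3 holds the middle place among the three numbers, with compound 1 lower and compound 2 higher. The next compound, compound 4 `O=[N+]([O-])c1ccccc1COc1ccc(OCCOCCNC2CCCCC2)cc1`, has nitro in place of hydrogen on an aromatic carbon, ortho to a large group, which turns benzyl into 2-nitrobenzyl (nitro in place of hydrogen on an aromatic carbon).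

Within the data shown here, the one measured step on an aromatic carbon is a 2.8-fold higher number from compound 1 to compound 3 (0.44 log units; beyond the scatter), a modest step with hydrogen in place of chloro, so the compound carrying chloro holds the lower number. Among the measured compounds shown here, it is a single case, and no measured compound carries nitro or any group at the place the nitro takes. The other measured step, an 8.1-fold lower number from compound 2 to compound 3 (0.91 log units; beyond the scatter), is also modest but lies at the chain end and says little about a change on the aromatic ring.

The precedent supports only a small expected shift toward a lower number, so the expected step is a 1.5-fold lower number from compound 3 to compound 4 (0.19 log units; within the scatter) and may not clear the usual scatter. Compound 4 is estimated at 4800 nM (expected range 1700 nM to 14000 nM) in this assay until a measurement is available.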

Compound 4, half-maximal inhibitory concentration: 2880 nM
The estimate for compound 4 lay 1.7-fold (0.22 log units) above the measured number, within the range that was stated.
By their numbers in this assay, from the lowest: compounds 1 and 4 (each within the scatter of the next); then compound 3; then compound 2.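

In this assay, nitro in place of hydrogen on the benzyl ring gives a 2.6-fold lower number from compound 3 to compound 4 (0.41 log units; beyond the scatter). This is a second case, after the chloro of compound 1, in which a group on this ring goes with a lower number than the plain benzyl of compound 3, and here the place is ortho to a large group. The step between the two substituted forms, a 1.1-fold higher number from compound 1 to compound 4 (0.04 log units; within the scatter), shows that 2-nitrophenyl and 4-chlorophenyl cannot be told apart on this read-out, so the ring accepts either group with no separable difference in the number. No measured information is available that bears on the reason for these shifts.

Compound 1 and compound 4 differ in both the group and its place on the ring, so the effect of each cannot be separated; chloro at the place of the nitro in compound 4, or nitro at the place of the chloro in compound 1, would divide the two. Also open, from the compounds shown here alone, is how far the trend extends to groups of another kind at this place, such as an amine or a carboxylic acid.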